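From piperidin-1-yl to pyrrolidin-1-yl on the carbonyl carbon

This account rests on a few compounds, and the source may have more. Where it says the series, first, only, none or still open, it means among the compounds named here.

Values in a functional assay on DU-145 cells (Homo sapiens) for inhibition, read by MTT assay, with a stated time of 48 h; a lower number here means a stronger inhibitor, a higher number a weaker inhibitor:
Compound 1 `CCn1c(/C=C2\SC(=O)N(CC(=O)N3CCCCC3)C2=O)nc2ccccc21`: > 50000 nM, a limit
Compound 2 `Cn1c(/C=C2\SC(=O)N(CC(=O)N3CCCCC3)C2=O)nc2ccccc21`: > 50000 nM, a limit
Compound 3 `CCn1c(/C=C2\SC(=O)N(CC(=O)N3CCc4cc(OC)c(OC)cc4C3)C2=O)nc2ccccc21`: > 50000 nM, a limit

Compound 2 gives only a limit, > 50000 nM, so no number anchors a step from it. The other two values are limits as well, and the whole series sits at the limit of > 50000 nM in this assay, at which 3 of the 3 values shown sit.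

Compound 4 `Cn1c(/C=C2\SC(=O)N(CC(=O)N3CCCC3)C2=O)nc2ccccc21` carries one change from compound 2: pyrrolidin-1-yl in place of piperidin-1-yl on a carbonyl carbon. Within the data shown here, the only measured step, a step that the two limits leave unreadable from compound 1 to compound 2, lies at a different place in the structure, and its size cannot be read. Among the measured compounds shown here, no measured step covers a change on this carbonyl carbon.

With compound 2 at its limit and no readable step to draw on, no step beyond the scatter is expected in this assay, and another reported limit is the likeliest outcome. The expected step is a step that the limit leaves unreadable from compound 2 to compound 4. Compound 4 is estimated at 60000 nM, with an expected range from 25000 nM to 150000 nM.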

Compound 4, half-maximal inhibitory concentration: > 50000 nM
Compound 4: only a limit was reported; the forecaster's own chance of this, stated with the estimate: 85%; the middle value does not contradict the limit.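

No step can be read from compound 2 to compound 4: both values are limits. The compounds shown leave open whether any change to the shared core or its side groups gives a measurable value in this assay, for the whole series stands at one reading: the limit of > 50000 nM in this assay, at which 4 of the 4 values shown sit.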